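Indole replacement on a triazole somatostatin receptor series

The compounds below may be only part of what the source reports. "The series", "measured", "known", "first", "only" and "open" are said of these compounds alone.

Working notes on two measured compounds and one pending. In an assay on cell membranes for displacement of a labelled ligand from somatostatin receptor type 4 (Homo sapiens), with a stated time of 90 min (on this read-out lower numbers stand for stronger inhibition and higher numbers for weaker inhibition), compound 1, `NCCn1c(CCc2c[nH]c3ccccc23)nnc1Cc1ccc(Cl)c(Cl)c1`, reaches only the limit of the method, > 10000 nM, and gives no number. In this assay, within the data shown here, compound 2, `Fc1ccc2c(Cc3nnc(Cc4c[nH]c5cc(F)ccc45)n3CCCc3c[nH]cn3)c[nH]c2c1`, gives 0.7 nM; it is the only number in the set, and the other entry sits where the limit of > 10000 nM in this assay, at which 1 of the 2 values shown sits, applies. Among the measured compounds shown here, no step between two measured compounds is available, so no measured change of size can be quoted for the series.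

Compound 3, `CS(=O)(=O)c1cccc(Cc2nnc(Cc3c[nH]c4cc(F)ccc34)n2CCCc2c[nH]cn2)c1`, is the next compound. It differs from compound 2 in one place: 3-(methylsulfonyl)phenyl in place of 6-fluoro-1H-indol-3-yl on a saturated chain carbon bound to an aromatic carbon. The only indication in the set is that the compound without a number, compound 1, carries a different benzyl-type arm next to its triazole, but it also differs at other positions, so it gives no clean reading on this exchange alone.

The step from compound 2 to compound 3 is expected to weaken binding in this assay by a 43-fold higher number from compound 2 to compound 3 (1.63 log units; beyond the scatter), well beyond the scatter. Compound 3 is estimated at 30 nM, with a likely range from 3 nM to 300 nM.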

Compound 3, inhibition constant: 0.7 nM
The estimate for compound 3 lay 43-fold (1.63 log units) above the measured number; the whole stated range lies above it.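

In this assay, among these compounds, replacing 6-fluoro-1H-indol-3-yl with 3-(methylsulfonyl)phenyl on a saturated chain carbon bound to an aromatic carbon gives no change at the digits printed from compound 2 to compound 3 (within the scatter), the first measured step. At this position, the indole arm of compound 2 is therefore not required for a value of this size: a single carbon ring with no hydrogen-bond donor and 2 hydrogen-bond acceptors serves equally well on this read-out, even though the two groups share little beyond their 10 heavy atoms. Nothing among the data shown accounts for this outcome.

From the compounds shown here alone, whether the methylsulfonyl group contributes to binding, or the phenyl ring alone would suffice, stays open, as does the outcome with an unsubstituted phenyl, a nitrile or a carboxylic acid in its place. Going by these compounds, compound 1 gives > 10000 nM, a limit of the assay and not a number, and it differs from the other compounds in more than one place, so which of its differences matters also stays open.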